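The source may report more compounds than this note shows. Statements on the series, on what has been measured and on what is new or still open speak of the compounds shown alone.

The measured compounds, with their values in a functional assay on MDA-MB-231 cells (Homo sapiens) for antiproliferative activity, read by MTT assay, with a stated time of 48 h; a higher number here means a weaker inhibitor of growth, a lower number a stronger inhibitor of growth:
Compound 1, `COC(=O)N1N=C(c2cccc(OC)c2)CC1c1cc(OC)c(OC)c(OC)c1`, gives 350 nM.
Compound 2, `CCOC(=O)N1N=C(c2cccc(OC)c2)CC1c1cc(OC)c(OC)c(OC)c1`, gives 9100 nM.
Compound 3, `COC(=O)N1N=C(c2ccc(OC)cc2)CC1c1cc(OC)c(OC)c(OC)c1`, gives 1990 nM.

Compound 1 and compound 3 differ in one place: 4-methoxyphenyl in place of 3-methoxyphenyl on a carbon with a double bond to nitrogen. In this assay that difference costs a 5.7-fold higher number from compound 1 to compound 3 (0.75 log units; beyond the scatter). Compound 2 is compound 1 with one change, (methyl in place of hydrogen on a saturated chain carbon bound to an oxygen next to a carbonyl group), and the step it made is a 26-fold higher number from compound 1 to compound 2 (1.41 log units; beyond the scatter). Compound 4, `CCOC(=O)N1N=C(c2ccc(OC)cc2)CC1c1cc(OC)c(OC)c(OC)c1`, has not yet been measured. It stands to compound 3 as compound 2 stands to compound 1, the change being (methyl in place of hydrogen on a saturated chain carbon bound to an oxygen next to a carbonyl group), made at the same place, so it is the same change, now on the core of compound 3 rather than that of compound 1. Within the data shown here, the expectation rests on that single earlier step, a 26-fold higher number from compound 1 to compound 2 (1.41 log units; beyond the scatter), and on nothing else, since no other pair in this set shows the change. The step from compound 3 to compound 4 is expected to be about a 20-fold higher number from compound 3 to compound 4 (1.30 log units; beyond the scatter). Compound 4 is therefore expected to give about 40000 nM in this assay, most likely between 10000 nM and 150000 nM.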

Compound 4, concentration for 50% growth inhibition: 2660 nM
The estimate for compound 4 lay 15-fold (1.18 log units) above the measured number; the whole stated range lies above it.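

In this assay, the change from methoxycarbonyl to ethoxycarbonyl on the core of compound 3 gives only a 1.3-fold higher number from compound 3 to compound 4 (0.13 log units; within the scatter), so it does not carry over with the size it had on the core of compound 1: the same change on two cores in this assay, a 26-fold higher number (1.41 log units; beyond the scatter) from compound 1 to compound 2 and a 1.3-fold higher number (0.13 log units; within the scatter) from compound 3 to compound 4, 19-fold (1.29 log units) apart, beyond the scatter of two such steps

The change from 3-methoxyphenyl to 4-methoxyphenyl also fails to carry over, since on the ethoxycarbonyl core it gives a 3.4-fold lower number from compound 2 to compound 4 (0.53 log units; beyond the scatter), the opposite direction to its step on the methoxycarbonyl core: the same change on two cores in this assay, a 5.7-fold higher number (0.75 log units; beyond the scatter) from compound 1 to compound 3 and a 3.4-fold lower number (0.53 log units; beyond the scatter) from compound 2 to compound 4, 19-fold (1.29 log units) apart, beyond the scatter of two such steps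

Among these compounds, in these four compounds, then, the size of each step depends on what stands at the other place, and a step read on one core cannot simply be transferred to the other, but with only one pair of steps for each change, this does not show why the two places interact or how far the interaction extends.

On these data alone, it remains open whether a longer chain, such as propoxycarbonyl, would follow compound 1 or compound 3 in its response. The same question stands for an amide in place of the ester, or for a chloro or hydroxy group in place of the methoxy group on the aryl substituent.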